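The source may hold more compounds than are shown below. What is called first, only, known or untested is meant among the compounds shown, and "the series" means these compounds.

In a functional assay on cells (Ovarian carcinoma cell, Homo sapiens) for cytotoxicity, read by sulforhodamine B assay, with a stated time of 48 h (on this read-out lower numbers stand for stronger inhibition of growth and higher numbers for weaker inhibition of growth), compound 1 `COc1nc2sc(C)cn2c1/C=C1/C(=O)Nc2ccccc21` gives 6290 nM. Going by the values given here, the only other measured compound, compound 2 `O=C1Nc2ccccc2C1=Cc1c(-c2ccncc2)nc2sccn12`, gives 2340 nM in this assay. Compound 1 therefore carries the higher of the two numbers, meaning the weaker inhibition of growth, and its gap to compound 2 lies beyond the usual scatter of repeated measurements. Compound 2 differs from compound 1 in more than one place, so the two values show only where each stands, not what any single change does.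

Compound 3 `COc1nc2sc(C)cn2c1/C=C1/C(=O)Nc2ccc(O)cc21` has not yet been measured in this assay. Its difference from compound 1 is this: hydroxy in place of hydrogen on an aromatic carbon. The hydroxy that enters brings one hydrogen-bond donor and one hydrogen-bond acceptor and sits on the six-membered aromatic ring of carbon only, part of the fused system of two rings in the shared core. Among the compounds with values here, no measured pair isolates this change, so any expectation rests on the two values shown and is loosely held. A modest step towards stronger inhibition is expected, a 1.8-fold lower number from compound 1 to compound 3 (0.25 log units; within the scatter), which may still fall within the scatter. Compound 3 is estimated at 3500 nM in this assay, with a range from 1200 nM to 10000 nM.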

Compound 3, concentration for 50% growth inhibition: 12900 nM
Compound 3: middle estimate off by 3.7-fold (0.57 log units), on the low side, outside the stated range (above it).
By their numbers in this assay, from the lowest: compound 2; then compound 1; then compound 3.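

Going by these compounds alone, this is the first pair that differs in only one place, so a single change can now be read directly. In this assay, placing a hydroxy on this aromatic carbon, meta to a fused ring and para to a fused ring, gives a 2.1-fold higher number from compound 1 to compound 3 (0.31 log units; beyond the scatter), a modest move towards weaker inhibition of growth. At this position on compound 1, then, adding a hydroxy with its hydrogen-bond donor and acceptor brings no gain in growth inhibition, and no measurement here explains why the number rises.

A single step at a single position cannot show whether the weaker inhibition is specific to the hydroxy or would also follow from another group on the same carbon, such as an amine or a fluorine atom. It also leaves open whether the same hydroxy would shift the number in the same direction on compound 2, which differs from compound 1 in more than one place, or at another carbon of this ring.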